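Ester chain length and cytotoxicity across four related compounds

This account rests on a few compounds, and the source may have more. Where it says the series, first, only, none or still open, it means among the compounds named here.

The measured compounds are:
compound 1 `CCCOC(=O)CCC(=O)N1CCN(CCCOc2cc3c(Nc4ccc(F)c(Cl)c4)ncnc3cc2OC)CC1`: 70.4%
compound 2 `CCCCOC(=O)CCC(=O)N1CCN(CCCOc2cc3c(Nc4ccc(F)c(Cl)c4)ncnc3cc2OC)CC1`: 64.1%
compound 3 `CCCCCCCCCCCCCCCCOC(=O)CCC(=O)N1CCN(CCCOc2cc3c(Nc4ccc(F)c(Cl)c4)ncnc3cc2OC)CC1`: 80%

All three share one core and differ only in the ester chain on the succinyl side. In a functional assay on A549 cells (Homo sapiens) for cytotoxicity, read by MTT assay, with a stated time of 24 h, tested at 60 uM (a lower number here means a stronger effect, a higher number a weaker effect of the compound at the concentration tested), compound 1 gives 70.4% and compound 2 gives 64.1%. The change between them is methyl in place of hydrogen on a saturated chain carbon, three bonds along the chain from an oxygen next to a carbonyl group and it made a number 6.3 percentage points lower from compound 1 to compound 2 (within the scatter). Compound 3, with the longest chain, gives 80% in this assay, which is a number 15.9 percentage points higher from compound 2 to compound 3 (beyond the scatter). The difference between the core of compound 1 and the core of compound 3 is not broken down here.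

Compound 4 `CCCCCCCCCCCCCCCCCOC(=O)CCC(=O)N1CCN(CCCOc2cc3c(Nc4ccc(F)c(Cl)c4)ncnc3cc2OC)CC1` has not yet been measured in this assay. It differs from compound 3 by methyl in place of hydrogen on a saturated chain carbon, ten or more bonds along the chain from an oxygen next to a carbonyl group. This is the same kind of change as that from compound 1 to compound 2, but the place along the chain is not the same: the new methyl sits further along the chain from an oxygen next to a carbonyl group than the earlier one did. Because the earlier step of this kind was a number 6.3 percentage points lower from compound 1 to compound 2 (within the scatter), a small step is expected here as well, estimated as a number 2 percentage points lower from compound 3 to compound 4 (within the scatter). Compound 4 is therefore expected to give about 78% in this assay, likely between 65% and 91%.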

Compound 4, a percentage reported as activity, at one concentration (the size of the read-out at that concentration, not a potency): 84.1%
Beside the measured number, compound 4's estimate is 6.1 percentage points below it, within the range that was stated.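

In this assay, the added methyl at the far end of the ester chain gave a number 4.1 percentage points higher from compound 3 to compound 4 (within the scatter), so this step cannot be told apart from the spread of repeated measurements. Set beside the earlier methyl step, it shows no difference that can be read between the two cores: the same change on two cores in this assay, a number 6.3 percentage points lower (within the scatter) from compound 1 to compound 2 and a number 4.1 percentage points higher (within the scatter) from compound 3 to compound 4, 10.4 percentage points apart, within the scatter of two such steps

The change therefore carried from the core of compound 1 to the core of compound 3 without a step beyond the scatter on either, but this does not show that its effect is the same on both, or that it has no effect, as the two small steps cannot resolve either point and the methyl sits at a different place along the chain in each pair.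

The compounds shown leave open how the read-out runs across the chain lengths lying between those of compound 2 and compound 3, a span that holds a number 15.9 percentage points higher from compound 2 to compound 3 (beyond the scatter), and an octyl ester would speak to this directly. They also leave open how a branched chain such as isopropyl, or a free carboxylic acid in place of the ester, would read in this assay.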